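The source may report more compounds than this note shows. Statements on the series, on what has been measured and on what is new or still open speak of the compounds shown alone.

Working notes on the series. The shared core carries a 4-chlorophenyl group in the three measured compounds: compound 1 `O=C1CS/C(=N/N=C/c2c(-c3ccc(Cl)cc3)[nH]c3ccccc23)N1Cc1ccco1`, compound 2 `CCC1S/C(=N\N=C\c2c(-c3ccc(Cl)cc3)[nH]c3ccccc23)NC1=O` and compound 3 `O=C1N/C(=N/N=C/c2c(-c3ccc(Cl)cc3)[nH]c3ccccc23)SC1CCO`. In an ADME assay on MRC5 cells (Homo sapiens) for cytotoxicity, read by fluorescence, with a stated time of 24 h (a lower number here means a stronger inhibitor, a higher number a weaker inhibitor), compound 1 gives 10800 nM, compound 2 gives 8800 nM and compound 3 gives 13200 nM. Among the compounds with values here, compound 2 is not set apart from either neighbour beyond the scatter: the gap to compound 1 is within the scatter, and the one measured step, a 1.5-fold higher number from compound 2 to compound 3 (0.18 log units; within the scatter), is also within the scatter.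

Compound 4 `CCC1S/C(=N\N=C\c2c(-c3ccc([N+](=O)[O-])cc3)[nH]c3ccccc23)NC1=O` is not yet measured in this assay. It differs from compound 2 by nitro in place of chloro on an aromatic carbon. Within the data shown here, no measured step touches the aromatic carbon of the six-membered aromatic ring of carbon only; the only measured step, a 1.5-fold higher number from compound 2 to compound 3 (0.18 log units; within the scatter), concerns the saturated chain and is within the scatter, so it gives no pointer to the size or direction of the present change. With nothing in the data speaking for a shift, the expectation for compound 4 is a number close to that of compound 2.

The step from compound 2 to compound 4 is therefore expected to be a 1.0-fold higher number from compound 2 to compound 4 (0.01 log units; within the scatter), within the scatter. Compound 4 is estimated at 9000 nM, with a range from 4000 nM to 20000 nM.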

Compound 4, half-maximal inhibitory concentration: 25200 nM
Beside the measured number, compound 4's estimate is 2.8-fold (0.45 log units) below it; measured number outside the range, above it.
By their numbers in this assay, from the lowest: compounds 2, 1, 3 and 4 (each within the scatter of the next, the first and the last beyond it).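

In this assay, within the data shown here, the change from 4-chlorophenyl to 4-nitrophenyl gives a 2.9-fold higher number from compound 2 to compound 4 (0.46 log units; beyond the scatter) and is the first step to leave the scatter, so this aromatic carbon, para to a large group, is a place where a replacement can move the number. The one earlier step, on the saturated chain, gave a 1.5-fold higher number from compound 2 to compound 3 (0.18 log units; within the scatter) and so had shown no substitution that moves the number beyond the scatter; the new step points towards a weaker inhibitor, though it rests on this single pair of compounds. Nothing available bears on why nitro in place of chloro has this effect.

On these data alone, a single replacement at this carbon gives no trend, so it remains open whether an amine, a methoxy group or a plain hydrogen there would stay close to compound 2 or move as far as compound 4. As far as these compounds go, it is also open whether the same replacement would act alike on the saturated chain variant of compound 3 or on the ring nitrogen substituted form of compound 1.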